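A few compounds are considered here, and "the series" means these few. Any claim that something is new, unique, unknown or untested is made for them only; others in the source may bear on it.

Working notes on the series. In a functional assay on MGC-803 cells (Homo sapiens) for inhibition, read by MTT assay, with a stated time of 72 h (a lower number here means a stronger inhibitor, a higher number a weaker inhibitor), compound 1 (`Cc1cc(Nc2cc(-c3ccccc3)[nH]n2)n2nc(SCc3ccc(Br)cc3)nc2n1`) gives 1110 nM, and compound 2 (`C#CCSc1nc2nc(C)cc(Nc3cc(-c4ccccc4)[nH]n3)n2n1`) gives 13400 nM, the higher of the two numbers. Compound 3 (`Cc1cc(Nc2cc(-c3ccccc3)[nH]n2)n2ncnc2n1`) follows from compound 2 by one change: hydrogen in place of propargylsulfanyl on an aromatic carbon. In short, hydrogen stands in place of propargylsulfanyl on an aromatic carbon, so the whole sulfur chain is gone.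

Among the measured compounds shown here, only one measured step bears on this: a 12-fold higher number from compound 1 to compound 2 (1.08 log units; beyond the scatter). For the measured compounds named here, that large step replaced the end of the chain on the sulfur but kept the sulfur, so no measured pair covers full removal of the chain. Going by that step alone, a further rise is expected in this assay, but a much smaller one, perhaps not beyond the scatter. The estimated change is a 1.6-fold higher number from compound 2 to compound 3 (0.22 log units; within the scatter). For compound 3 the expected value is 22000 nM, with an estimated range of 7000 nM to 70000 nM.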

Compound 3, half-maximal inhibitory concentration: 21700 nM
Compound 3: the middle estimate sits 1.0-fold (0.01 log units) above what was measured; measured number inside the range.
By their numbers in this assay, from the lowest: compound 1; then compounds 2 and 3 (each within the scatter of the next).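

In this assay the step of a 1.6-fold higher number from compound 2 to compound 3 (0.21 log units; within the scatter) lies within the scatter, so full removal of the sulfur chain gives a compound that cannot be told apart from the propargylsulfanyl compound. Replacing (4-bromobenzyl)sulfanyl with hydrogen gives a 20-fold higher number from compound 1 to compound 3 (1.29 log units; beyond the scatter) and so shows that, among these three compounds, only the (4-bromobenzyl)sulfanyl group stands apart at this aromatic carbon, while the sulfur kept in compound 2 brings no separation from hydrogen. Nothing measured here explains these steps. Still open, on these data alone, is whether the bromine matters or the benzyl group alone suffices, which a plain benzylsulfanyl group would show. Also open, as far as these compounds go, is how an amine or a longer alkyl chain on sulfur would read at this carbon.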